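Swapping the Aryl Group of Compound 3 for 4-(tert-butyl)phenyl

A few compounds are considered here, and "the series" means these few. Any claim that something is new, unique, unknown or untested is made for them only; others in the source may bear on it.

- Compound 1 `Cc1ccc(C)c(/C=C/[C@](C)(O)CC[C@@H]2[C@@]3(C)CCCC(C)(C)[C@@H]3CC[C@@]2(C)O)c1`: 176 nM
- Compound 2 `Cc1cccc(/C=C/[C@](C)(O)CC[C@@H]2[C@@]3(C)CCCC(C)(C)[C@@H]3CC[C@@]2(C)O)c1C`: 3500 nM
- Compound 3 `CC1(C)CCC[C@]2(C)[C@@H](CC[C@@](C)(O)/C=C/c3ccc(Cl)nc3)[C@](C)(O)CC[C@@H]12`: 275 nM

In a functional assay on PC-3 cells (Homo sapiens) for cytotoxicity, read by MTT assay, with a stated time of 48 h (on this read-out lower numbers stand for stronger inhibition and higher numbers for weaker inhibition), compound 3 gives 275 nM. It sits within the scatter of one neighbour, as a 1.6-fold higher number from compound 1 to compound 3 (0.19 log units; within the scatter) shows, and far from the other, as a 13-fold lower number from compound 2 to compound 3 (1.10 log units; beyond the scatter) shows.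

The next compound is compound 4 `CC(C)(C)c1ccc(/C=C/[C@](C)(O)CC[C@@H]2[C@@]3(C)CCCC(C)(C)[C@@H]3CC[C@@]2(C)O)cc1`, which keeps the shared core and carries 4-(tert-butyl)phenyl in place of 6-chloropyridin-3-yl on a double-bonded chain carbon bound to a double-bonded chain carbon.

All three measured steps are swaps at this same place, so all of them bear on the change. They point in no single direction: a 1.6-fold higher number from compound 1 to compound 3 (0.19 log units; within the scatter) stayed within the scatter, while a 20-fold higher number from compound 1 to compound 2 (1.30 log units; beyond the scatter) was large. None of them involves 4-(tert-butyl)phenyl, so a large step in this assay cannot be excluded, but none beyond the scatter is firmly expected. The expected change is a 1.5-fold higher number from compound 3 to compound 4 (0.16 log units; within the scatter). For compound 4 the estimated value is 400 nM, with an expected range of 100 nM to 2500 nM.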

Compound 4, half-maximal inhibitory concentration: 3800 nM
Estimate against measurement, compound 4: 9.5-fold (0.98 log units) below; the whole stated range lies below it.
By their numbers in this assay, from the lowest: compounds 1 and 3 (each within the scatter of the next); then compounds 2 and 4 (each within the scatter of the next).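

In this assay, a 14-fold higher number from compound 3 to compound 4 (1.14 log units; beyond the scatter) and a 22-fold higher number from compound 1 to compound 4 (1.33 log units; beyond the scatter) show that a large loss at this place on the chain is not confined to compound 2, since 4-(tert-butyl)phenyl brings one too. With a 1.1-fold higher number from compound 2 to compound 4 (0.04 log units; within the scatter) as well, the four aryl groups now fall into two sets: 2,5-dimethylphenyl and 6-chloropyridin-3-yl give the lower numbers, while 2,3-dimethylphenyl and 4-(tert-butyl)phenyl give the higher ones. A ring of carbon only does not decide the set, as compound 1 has such a ring and still stays with compound 3.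

Nothing available accounts for this split. On these data alone, whether a plain phenyl, or a phenyl carrying an amine or a carboxylic acid, would stand with compound 1 or with compound 4 remains open.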